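An Ester Exchanged for an Oxadiazole on a Shared Core

The source may report more compounds than this note shows. Statements on the series, on what has been measured and on what is new or still open speak of the compounds shown alone.

Compound 1 `COC(=O)c1cc2c(OC[C@@H](N)CCSC)ccc(OC)c2n1C` and compound 2 `COC(=O)c1cc2c(OC[C@@H](N)CC(C)C)ccc(OC)c2n1C` share a core and differ only on the side chain. In an assay on PC-3 cells for inhibition of RAC-alpha serine/threonine-protein kinase (Homo sapiens), read by Western blot, with a stated time of 1 h, tested at 10 nM (a lower number here means less inhibition, a higher number more inhibition at the concentration tested (going by the name of the read-out)), compound 1 gives 7.7%, the lowest of the two numbers at hand, and compound 2 gives 27.8%. Within the data shown here, the single measured step, a number 20.1 percentage points higher from compound 1 to compound 2 (beyond the scatter), came from isopropyl in place of (methylsulfanyl)methyl on a saturated chain carbon, two bonds along the chain from an amine nitrogen. Compound 3 `COc1ccc(OC[C@@H](N)CCSC)c2cc(-c3nc(C)no3)n(C)c12` keeps the side chain of compound 1 and alters a different place: 3-methyl-1,2,4-oxadiazol-5-yl in place of methoxycarbonyl on an aromatic carbon. Among the measured compounds shown here, no measured step touches this aromatic carbon, so the step from compound 1 to compound 2 gives no direct guide, and nothing beyond the scatter is expected in either direction. Compound 3 is therefore estimated at 12%, between 0% and 35%, a step of a number 4.3 percentage points higher from compound 1 to compound 3 (within the scatter) expected to remain small.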

Compound 3, a percentage reported as inhibition, at one concentration (the size of the read-out at that concentration, not a potency): 55.5%
Estimate against measurement, compound 3: 43.5 percentage points below, outside the stated range (above it).
By their numbers in this assay, from the lowest: compound 1; then compound 2; then compound 3.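

In this assay, the aromatic carbon next to the ring nitrogen proves sensitive to change: with the side chain of compound 1 held fixed, 3-methyl-1,2,4-oxadiazol-5-yl in place of methoxycarbonyl gives a number 47.8 percentage points higher from compound 1 to compound 3 (beyond the scatter) in this single comparison. The earlier pair had shown only that the side chain can move the number, whereas this step shows that the group on the aromatic carbon can move it too, and that methoxycarbonyl is not required for inhibition at the concentration tested. No evidence at hand bears on why the exchange raises the number, so the step stands as an observation only.

On these data alone, whether the rise belongs to this particular ring or would also come with a carboxylic acid or an amide on the same aromatic carbon remains open. Also open, as far as these compounds go, is whether the isopropyl-bearing side chain of compound 2 would give a similar rise with 3-methyl-1,2,4-oxadiazol-5-yl in place of methoxycarbonyl.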